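The compounds below may be only part of what the source reports. "The series", "measured", "known", "first", "only" and "open" are said of these compounds alone.

In an ADME assay on HuDe cells (Homo sapiens) for cytotoxicity, read by MTT assay, with a stated time of 72 h (a lower number here means a stronger inhibitor, a higher number a weaker inhibitor), three compounds sharing one core have been measured. Compound 1 `NC(=O)c1ccccc1NC(=O)COc1ccccc1`, with hydrogen on the aromatic carbon in question, gives 523000 nM. Its chloro analogue, compound 2 `NC(=O)c1cc(Cl)ccc1NC(=O)COc1ccccc1`, gives 808000 nM, and its iodo analogue, compound 3 `NC(=O)c1cc(I)ccc1NC(=O)COc1ccccc1`, gives 318000 nM. Two steps place the iodo analogue in this small set: a 1.6-fold lower number from compound 1 to compound 3 (0.22 log units; within the scatter), and a 2.5-fold lower number from compound 2 to compound 3 (0.40 log units; beyond the scatter). It therefore sits level with the hydrogen analogue and apart from the chloro analogue.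

The next compound, compound 4 `Cc1ccc(NC(=O)COc2ccccc2)c(C(N)=O)c1`, has methyl in place of iodo on an aromatic carbon. For the measured compounds named here, no methyl compound has been measured, so the evidence is indirect. Chloro in place of hydrogen gave a 1.5-fold higher number from compound 1 to compound 2 (0.19 log units; within the scatter), which, like the iodo step from compound 1, stays within the scatter. Only the exchange of one halogen for the other exceeded the scatter, and modestly. Methyl is thus expected to fall within the narrow band spanned by these three compounds, with at most a slight lean towards a higher number and no step clearly beyond the scatter. The expected change is a 1.5-fold higher number from compound 3 to compound 4 (0.18 log units; within the scatter). Compound 4 is estimated at 480000 nM, with an expected range from 240000 nM to 950000 nM.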

Compound 4, half-maximal inhibitory concentration: 99300 nM
The estimate for compound 4 lay 4.8-fold (0.68 log units) above the measured number; the whole stated range lies above it.
By their numbers in this assay, from the lowest: compound 4; then compounds 3, 1 and 2 (each within the scatter of the next, the first and the last beyond it).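

In this assay, this position turns out to be able to move the number beyond the scatter from the hydrogen compound, which neither halogen did: methyl gives a 5.3-fold lower number from compound 1 to compound 4 (0.72 log units; beyond the scatter), while chloro and iodo in place of hydrogen both stayed within the scatter. Methyl also stands apart from both halogens, with a 3.2-fold lower number from compound 3 to compound 4 (0.51 log units; beyond the scatter) and an 8.1-fold lower number from compound 2 to compound 4 (0.91 log units; beyond the scatter), so compound 4 has the lowest number of the four, and its steps to all three others lie beyond the scatter. Iodo and methyl each count as one heavy atom, with no ring, no hydrogen-bond donors or acceptors and no net charge, so these counts do not separate them, and no measurement at hand accounts for the step.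

The compounds shown leave open whether this lower number belongs to methyl alone or extends to other groups on this aromatic carbon, such as ethyl, methoxy, an amine or a carboxylic acid. Also open, from the compounds shown here alone, is where fluoro and bromo would fall, and so whether chloro and iodo speak for the halogens as a whole.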